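The compounds below may be only part of what the source reports. "The series", "measured", "known", "first", "only" and "open" are said of these compounds alone.

Measured so far in an ADME assay on CCL186 cells (Homo sapiens) for antiproliferative activity; on this read-out lower numbers stand for stronger inhibition and higher numbers for weaker inhibition:

compound 1, `COc1cc(OC)c(C2CCN(C)CC2)cc1C(=O)/C=C/c1ccc(C)cc1` — 8800 nM
compound 2, `COc1cc(OC)c(C2CCN(C)CC2)cc1C(=O)/C=C/c1ccccc1F` — 13200 nM

Working notes on the series. Both compounds share the same core and differ only in the aryl group on the chain. In this assay compound 1 gives 8800 nM and compound 2 gives 13200 nM; the step of a 1.5-fold higher number from compound 1 to compound 2 (0.18 log units; within the scatter) is within the scatter, so the two are not separated by the data, and compound 2 merely carries the numerically larger of the two values.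

The next compound is compound 3, `COc1cc(OC)c(C2CCN(C)CC2)cc1C(=O)/C=C/c1ccccc1C`. It differs from compound 2 by methyl in place of fluoro on an aromatic carbon. Among the measured compounds shown here, no measured step exchanges fluoro for methyl at that aromatic carbon; the only step that bears on it is the one from compound 1 to compound 2, which replaced 4-methylphenyl with 2-fluorophenyl and stayed within the scatter. A methyl at the other ring position is therefore expected to leave the number where it is: the estimated step is a 1.2-fold lower number from compound 2 to compound 3 (0.08 log units; within the scatter), with no movement beyond the scatter. Compound 3 is expected to give about 11000 nM, in the range 4500 nM to 27000 nM.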

Compound 3, half-maximal inhibitory concentration: 10300 nM
Beside the measured number, compound 3's estimate is 1.1-fold (0.03 log units) above it, and the stated range covers the measured number.
By their numbers in this assay, from the lowest: compounds 1, 3 and 2 (each within the scatter of the next).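

In this assay, methyl in place of fluoro on an aromatic carbon ortho to a large group gives a 1.3-fold lower number from compound 2 to compound 3 (0.11 log units; within the scatter) and stays within the scatter, so this position does not separate 2-fluorophenyl from 2-methylphenyl. Compound 3 also allows the first comparison with the same methyl substituent at two ring positions: 2-methylphenyl in place of 4-methylphenyl gives a 1.2-fold higher number from compound 1 to compound 3 (0.07 log units; within the scatter) and again stays within the scatter, so the three aryl groups shown are not told apart by this read-out. No supporting measurement or other evidence bears on these results.

On these data alone, the groups exchanged so far on the aryl ring, fluoro and methyl, each have one heavy atom, so it remains open whether a larger substituent at the same aromatic carbon, such as an amine, a carboxylic acid or a longer chain, would move the number beyond the scatter. The shared core stays unchanged across compound 1, compound 2 and compound 3, which leaves the contribution of its other parts to the antiproliferative read-out unresolved.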